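Replacing the amide of compound 3 with a butyl ester

The source may hold more compounds than are shown below. What is called first, only, known or untested is meant among the compounds shown, and "the series" means these compounds.

Three measured compounds share one core and differ only in the group on the amide-type nitrogen: compound 1 `CC(C)NC(=O)/C=C/c1ccccc1`, compound 2 `CC(C)CNC(=O)/C=C/c1ccccc1` and compound 3 `C=CCNC(=O)/C=C/c1ccccc1`. In a functional assay on the whole organism for inhibition, with Brassica rapa subsp. chinensis as the target, with a stated time of 3 days, tested at 100 ppm (on this read-out lower numbers stand for less inhibition of growth and higher numbers for more inhibition of growth at the one concentration tested), compound 1 gives 76%, compound 2 gives 78% and compound 3 gives 64%. Compound 3 thus stands lowest of the three: a number 12 percentage points lower from compound 1 to compound 3 (beyond the scatter) and a number 14 percentage points lower from compound 2 to compound 3 (beyond the scatter) are both beyond the scatter, whereas a number 2 percentage points higher from compound 1 to compound 2 (within the scatter) is not.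

Compound 4 `CCCCOC(=O)/C=C/c1ccccc1` is not yet measured. Its difference from compound 3 is butoxy in place of allylamino on a carbonyl carbon. Within the data shown here, none of the measured steps bears directly on this change: each of them swaps one group for another on the amide-type nitrogen, whereas here the whole allylamino group leaves the carbonyl carbon and butoxy enters. The measured steps only show that varying the group on the nitrogen shifts the read-out modestly, at most by a number 14 percentage points lower from compound 2 to compound 3 (beyond the scatter). With no measured ester for comparison, the direction of the step cannot be read from the data, and a wide range is the honest answer.

Compound 4 is therefore estimated at 55%, with a range from 25% to 80%. This estimate means an expected step of a number 9 percentage points lower from compound 3 to compound 4 (within the scatter).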

Compound 4, percent growth inhibition at one concentration: 0%
Compound 4: the middle estimate sits 55 percentage points above what was measured, outside the stated range (below it).
By their numbers in this assay, from the lowest: compound 4; then compound 3; then compounds 1 and 2 (each within the scatter of the next).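

In this assay, the group on the carbonyl carbon proves decisive in a way the earlier nitrogen swaps could not show: butoxy in place of allylamino gives the large step (a number 64 percentage points lower from compound 3 to compound 4 (beyond the scatter)), and the same holds for butoxy in place of isobutylamino (a number 78 percentage points lower from compound 2 to compound 4 (beyond the scatter)) and in place of isopropylamino (a number 76 percentage points lower from compound 1 to compound 4 (beyond the scatter)). All three amides, whichever group they carry on the nitrogen, thus lie far above compound 4, which shows no growth inhibition at the one concentration tested, so the read-out depends much more on keeping an amino group on this carbonyl carbon than on which of these three groups that nitrogen bears. Nothing available here bears on what lies behind this drop.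

The compounds shown cannot separate the oxygen that enters from the butyl chain it carries, and a butylamino group on the same carbonyl carbon would be the direct test of that. Also open, on these data alone, is how a methoxy group, a free carboxylic acid or a dialkylamino group, which has no amide hydrogen, would behave at this place.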